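The compounds below may be only part of what the source reports. "The series", "measured", "known", "first", "only" and "open" are said of these compounds alone.

In a functional assay on MCF7 cells (Homo sapiens) for cytotoxicity (a higher number here means a weaker inhibitor, a lower number a stronger inhibitor), compound 3 `CCOc1ccc2nc(NC(=O)CCCCC(=O)NO)sc2c1` gives 8.72 ug/mL and compound 1 `O=C(CCCCCCC(=O)Nc1nc2ccccc2s1)NO` gives 6.61 ug/mL, two values within the usual scatter of each other. Compound 2 `CS(=O)(=O)c1ccc2nc(NC(=O)CCCCC(=O)NO)sc2c1` reads > 30 ug/mL, which is a limit of the assay and not a number. Within the data shown here, the only measured step, an at least 3.4-fold lower number from compound 2 to compound 3 (0.53 log units; beyond the scatter), shows that swapping one group for another on an aromatic carbon can matter, but it starts from that limit and involves no hydrogen. Compound 4 `O=C(CCCCC(=O)Nc1nc2ccccc2s1)NO` carries hydrogen in place of ethoxy on an aromatic carbon. No step beyond the scatter is therefore expected in this assay, and the expected change is a 1.1-fold lower number from compound 3 to compound 4 (0.04 log units; within the scatter). For compound 4 the estimated value is 8 ug/mL, with an expected range from 3.5 ug/mL to 20 ug/mL.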

Compound 4, half-maximal inhibitory concentration: 4.02 ug/mL
Estimate against measurement, compound 4: 2.0-fold (0.30 log units) above, within the range that was stated.
By their numbers in this assay, from the lowest: compounds 4, 1 and 3 (each within the scatter of the next, the first and the last beyond it). At a limit, above all of these: compound 2.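

Removing ethoxy from this aromatic carbon costs nothing in this assay, and hydrogen instead gives a 2.2-fold lower number from compound 3 to compound 4 (0.34 log units; beyond the scatter). Hydrogen can also be set against methylsulfonyl here, but the value of compound 2 is a limit, so an at least 7.4-fold lower number from compound 2 to compound 4 (0.87 log units; beyond the scatter) gives only a minimum size. The change on the saturated chain, hydroxycarbamoyl in place of 2-(hydroxycarbamoyl)ethyl, stays within the scatter, at a 1.6-fold lower number from compound 1 to compound 4 (0.22 log units; within the scatter).

Going by these compounds, whether any group on this carbon can give a lower number than hydrogen remains open. An amine, a fluorine atom or a carboxylic acid there would help to answer that.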